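Hydrogen in Place of the Bromophenyl Carbonyl Group

The source may report more compounds than this note shows. Statements on the series, on what has been measured and on what is new or still open speak of the compounds shown alone.

Of the compounds shown here, two have been tested in an ADME assay on HepG2 cells (Homo sapiens) for cytotoxicity, read by CellTiter-Glo and resazurin assay, with a stated time of 72 h; a higher number here means that more compound is needed for the effect, a lower number that less compound is needed. Compound 1 `CC(C)N(Cc1cccc(OCCCCCC(=O)O)c1)C(=O)c1ccc(-c2cc3ccccc3n2S(=O)(=O)c2ccccc2)cc1` gives in this assay only a limit, > 26000 nM. Compound 2 `CCCN(Cc1ccc(OCCCCCC(=O)OCC)cc1)C(=O)c1ccc(Br)cc1` likewise gives in this assay only a limit, > 26000 nM. Compound 2 thus stands at the limit of > 26000 nM in this assay, at which 2 of the 2 values shown sit, so no order between the two compounds can be read. Compound 3 `CCCNCc1ccc(OCCCCCC(=O)OCC)cc1` differs from compound 2 by hydrogen in place of (4-bromophenyl)carbonyl on an amine nitrogen, in words hydrogen in place of (4-bromophenyl)carbonyl on an amine nitrogen. Within the data shown here, no measured step exists for this change, so no shift beyond the usual scatter is anticipated. The expected step from compound 2 to compound 3 is a step that the limit leaves unreadable from compound 2 to compound 3. Compound 3 is therefore estimated at 30000 nM, within 15000 nM to 80000 nM, most likely again reported only as a limit.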

Compound 3, half-maximal effective concentration: > 26000 nM
Compound 3 ended at the assay's limit; the forecaster's own chance of this, stated with the estimate: 80%; the middle value does not contradict the limit.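

No step can be read from compound 2 to compound 3, since both results are limits rather than numbers: the limit of > 26000 nM in this assay, at which 3 of the 3 values shown sit. The compounds shown leave open whether hydrogen in place of (4-bromophenyl)carbonyl changes the half-maximal effective concentration at all.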